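A few compounds are considered here, and "the series" means these few. Any claim that something is new, unique, unknown or untested is made for them only; others in the source may bear on it.

Compound 2 `CC1c2cc(Cl)ccc2C(=O)N1c1cccnc1` and compound 1 `O=C1c2ccc(Cl)cc2CN1c1cccnc1` share one core. In an ADME assay on microsomes from liver (Homo sapiens) for metabolic stability, read by LC-MS, using NADPH, with stated times of 10 min and 30 min (on this read-out lower numbers stand for slow clearance and higher numbers for fast clearance), compound 2 gives 12.2 mL/min/kg, and compound 1 gives 12.8 mL/min/kg. The change between them is hydrogen in place of methyl on a saturated ring carbon, and it made a step of a 1.0-fold higher number from compound 2 to compound 1 (0.02 log units; within the scatter). Compound 3 `CC(=O)N[C@@H]1CCCc2c1cncc2N1C(=O)c2ccc(Cl)cc2[C@H]1C` is built on another core; the difference between the two cores is not broken down here. In this assay compound 3 gives only a limit, < 3.5 mL/min/kg, which is the limit of < 3.5 mL/min/kg in this assay, at which 1 of the 3 values shown sits. Compound 4 `CC(=O)N[C@@H]1CCCc2c1cncc2N1Cc2cc(Cl)ccc2C1=O` differs from compound 3 by hydrogen in place of methyl on a saturated ring carbon. This is the same kind of change as that from compound 2 to compound 1, though here the place is next to the ring atom that bears a large group rather than a pyridin-3-yl group. The expected step is a step that the limit leaves unreadable from compound 3 to compound 4, resting on the earlier step of a 1.0-fold higher number from compound 2 to compound 1 (0.02 log units; within the scatter). Compound 4 is therefore estimated at 3 mL/min/kg, likely between 1.5 mL/min/kg and 6 mL/min/kg, and may again return only a limit.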

Compound 4, clearance: < 3.5 mL/min/kg
Compound 4: no number, only a limit; the forecaster's own chance of this, stated with the estimate: 60%; the middle value is on the limit's open side.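

Compound 3 and compound 4 each give only a limit in this assay, so the step between them cannot be read: the limit of < 3.5 mL/min/kg in this assay, at which 2 of the 4 values shown sit.

The compounds shown leave open how far apart the clearances of compound 3 and compound 4 truly lie, and so whether swapping methyl for hydrogen matters on their core.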